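A few compounds are considered here, and "the series" means these few. Any claim that something is new, unique, unknown or untested is made for them only; others in the source may bear on it.

Two sulfated alkyl chains have so far been measured in a functional assay on WEHI-164 cells (Mus musculus) for antiproliferative activity, read by MTT assay, with a stated time of 96 h; on this read-out lower numbers stand for stronger inhibition and higher numbers for weaker inhibition. Compound 1 `CCCCCCCCCCCCCCCCCOS(=O)(=O)O` gives 400 ug/mL in this assay. Compound 2 `CC(C)CCCC(CCCC(C)CCC[C@H](C)COS(=O)(=O)O)COS(=O)(=O)O` gives 230 ug/mL in this assay, the lower of the two numbers, yet this gap lies within the usual scatter, so no real order between compound 1 and compound 2 can be claimed. Compound 3 `CC(C)CCCC(CCCC(C)CCCC(C)CCOS(=O)(=O)O)COS(=O)(=O)O` has not yet been measured. It differs from compound 2 in one place: 1-methyl-3-(sulfooxy)propyl in place of 1-((sulfooxy)methyl)ethyl on a saturated chain carbon, nine bonds along the chain from an oxygen on an unsaturated carbon. Going by the values given here, no step between measured compounds that differ in a single place is available, so the size of this change cannot be read off from earlier data. Shifting one sulfate group by a single carbon along a long chain seems unlikely to move the number far. Compound 3 is therefore expected to give about 230 ug/mL, with a likely range from 100 ug/mL to 500 ug/mL. The step of no change at the digits printed from compound 2 to compound 3 (within the scatter) in this assay is expected to be none beyond the scatter.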

Compound 3, half-maximal inhibitory concentration: 300 ug/mL
Beside the measured number, compound 3's estimate is 1.3-fold (0.12 log units) below it; the range from low to high includes it.
By their numbers in this assay, from the lowest: compounds 2, 3 and 1 (each within the scatter of the next).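

The change to 1-methyl-3-(sulfooxy)propyl in place of 1-((sulfooxy)methyl)ethyl gives a 1.3-fold higher number from compound 2 to compound 3 (0.12 log units; within the scatter) in this assay. Going by these compounds alone, this is the first step read between two measured compounds that differ in one place. It shows that this position, on a saturated chain carbon, nine bonds along the chain from an oxygen on an unsaturated carbon, accepts this particular swap with no difference that can be told apart from repeat measurements, and nothing on hand speaks to what lies behind that result.

A single step at a single position says nothing about larger changes there. The compounds shown leave open whether a carboxylic acid in place of the sulfooxy group, or a much longer chain carrying that group, would shift the number beyond the scatter.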